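Working notes: amine variation on the shared core

The source may report more compounds than this note shows. Statements on the series, on what has been measured and on what is new or still open speak of the compounds shown alone.

Compound 1 `Cc1ccc2c(NCc3ccc(NC(=O)C4CCN(Cc5ccccc5)CC4)cc3)nc(N3CCC3)nc2c1` and compound 2 `Cc1ccc2c(NCc3ccc(NC(=O)C4CCN(Cc5ccccc5)CC4)cc3)nc(N3CCN[C@@H](C)C3)nc2c1` share a core and differ only in the group on an aromatic carbon, where compound 2 carries 3-methylpiperazin-1-yl in place of azetidin-1-yl. In a functional assay on SV5A8 cells (Homo sapiens) for cytotoxicity (on this read-out higher numbers stand for weaker inhibition and lower numbers for stronger inhibition), compound 1 gives only a limit, > 8500 nM. In this assay compound 2 likewise gives only a limit, > 8860 nM. The step that the two limits leave unreadable from compound 1 to compound 2 is therefore of unreadable size, since both values sit at limits (the limit of > 8500 nM in this assay, at which 1 of the 2 values shown sits, (the limit of > 8860 nM in this assay, at which 1 of the 2 values shown sits)), and compound 2 stands at one of these limits with no number of its own to compare against. Compound 3 `Cc1ccc2c(NCc3ccc(NC(=O)C4CCN(Cc5ccccc5)CC4)cc3)nc(N3CCC(N4CCCC4)CC3)nc2c1` is not yet measured; it differs from compound 2 by 4-(pyrrolidin-1-yl)piperidin-1-yl in place of 3-methylpiperazin-1-yl on an aromatic carbon. Among the compounds with values here, the only measured step concerns the same aromatic carbon but is unreadable, so it supplies neither a direction nor a size for the new change. The expectation for compound 3 in this assay is therefore that it also lands at or near the limit, and the step that the limit leaves unreadable from compound 2 to compound 3 is expected to be none beyond the scatter. Compound 3 is estimated at 9000 nM in this assay, in the range 2500 nM to 30000 nM.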

Compound 3, half-maximal inhibitory concentration: > 8090 nM
Compound 3 gave a limit, no number; the forecaster's own chance of this, stated with the estimate: 75%; the middle value does not contradict the limit.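

In this assay compound 3 gives > 8090 nM as a limit and no number, so the steps to compound 3 from compound 1 and from compound 2 cannot be read. The compounds shown leave open whether azetidin-1-yl, 3-methylpiperazin-1-yl and 4-(pyrrolidin-1-yl)piperidin-1-yl differ at all in this read-out on the shared core.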